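The source may hold more compounds than are shown below. What is called first, only, known or untested is meant among the compounds shown, and "the series" means these compounds.

In a functional assay on HeLa cells (Homo sapiens) for antiproliferative activity, read by MTT assay, with a stated time of 72 h (a higher number here means a weaker inhibitor, a lower number a stronger inhibitor), compound 1 `CCC/C=C/C(=O)Nc1cccc(Oc2nc(Nc3ccn(C)n3)nc3c2CSCC3)c1` gives 17000 nM, the lower of the two exact numbers. Compound 3 `CC(C)/C=C/C(=O)Nc1cccc(Oc2nc(Nc3ccn(C)n3)nc3c2CSCC3)c1` gives 40100 nM. Compound 2 `CC(C)=CC(=O)Nc1cccc(Oc2nc(Nc3ccn(C)n3)nc3c2CSCC3)c1` reaches a limit of the assay, > 50000 nM. Compound 4 `CCC/C=C/C(=O)Nc1cccc(Oc2nc(Nc3cccc(C#N)c3)nc3c2CSCC3)c1` carries a different change: 3-cyanophenyl in place of 1-methyl-1H-pyrazol-3-yl on a nitrogen on an aromatic ring, with 3-cyanophenyl in place of 1-methyl-1H-pyrazol-3-yl on a nitrogen on an aromatic ring. For the measured compounds named here, no measured step touches that place. The measured steps all alter the group on the carbonyl carbon, and they bear only indirectly: an at least 2.9-fold higher number from compound 1 to compound 2 (0.46 log units; beyond the scatter) and a 2.4-fold higher number from compound 1 to compound 3 (0.37 log units; beyond the scatter), while an at least 1.2-fold lower number from compound 2 to compound 3 (0.09 log units; that floor lies within the scatter). They give no direction for this change, so no shift beyond the scatter is expected, and the expected step is a 1.2-fold lower number from compound 1 to compound 4 (0.08 log units; within the scatter). For compound 4 the estimate is 14000 nM, with an expected range of 4000 nM to 45000 nM.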

Compound 4, half-maximal inhibitory concentration: 7220 nM
Compound 4: middle estimate off by 1.9-fold (0.29 log units), on the high side; the measured number falls inside the stated range.
By their numbers in this assay, from the lowest: compound 4; then compound 1; then compound 3. At a limit, above all of these: compound 2.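

In this assay, the group on the nitrogen on an aromatic ring also affects the read-out: 3-cyanophenyl in place of 1-methyl-1H-pyrazol-3-yl gives a 2.4-fold lower number from compound 1 to compound 4 (0.37 log units; beyond the scatter). Earlier changes all altered the group on the carbonyl carbon, and neither step from compound 1 lowered the number. No information shown here bears on the reason for this step.

Going by these compounds, it remains open whether a plain phenyl group would give the same shift, or whether an amine or a carboxylic acid could replace the nitrile. Whether the step carries over to the chain of compound 3 is also unknown.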